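This account rests on a few compounds, and the source may have more. Where it says the series, first, only, none or still open, it means among the compounds named here.

Of the compounds shown here, three sharing one core have been measured in an in vitro functional assay on cells for antagonist activity at B1 bradykinin receptor (Homo sapiens), read by luminescence and calcium flux, with a stated time of 2 h (on this read-out higher numbers stand for weaker inhibition and lower numbers for stronger inhibition), and they differ only in the group attached to the amide-type nitrogen. Compound 1 `Cc1ccc(S(=O)(=O)N2C=CNC(=O)[C@H]2CC(=O)N[C@@H]2CCCc3ccccc32)cc1` gives 3.3 nM in this assay. Compound 2 `Cc1ccc(S(=O)(=O)N2C=CNC(=O)[C@H]2CC(=O)N[C@H](C)c2ccccc2)cc1` gives 836 nM. Compound 3 `CCN1CC[C@H](NC(=O)C[C@@H]2C(=O)NC=CN2S(=O)(=O)c2ccc(C)cc2)C(C)(C)C1` gives 0.63 nM, the lowest of the three numbers. The step of a 250-fold higher number from compound 1 to compound 2 (2.40 log units; beyond the scatter) shows how strongly this position matters, while a 5.2-fold lower number from compound 1 to compound 3 (0.72 log units; beyond the scatter) and a 1300-fold lower number from compound 2 to compound 3 (3.12 log units; beyond the scatter) show that the ring carrying the amine nitrogen does best of the three.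

Compound 4 `Cc1ccc(S(=O)(=O)N2C=CNC(=O)[C@H]2CC(=O)N[C@H]2CCN(Cc3ccccc3)CC2(C)C)cc1` keeps that ring and changes only what sits on it: phenyl in place of methyl on a saturated chain carbon bound to an amine nitrogen in a ring. Going by the values given here, no measured step touches this position, so the measured steps bear on it only indirectly. They show that the amide-type nitrogen region tolerates a large group with an aromatic ring in compound 1 but not a smaller one in compound 2, without saying how a phenyl further out on the amine will behave. The expectation is therefore a small step, likely within the scatter, expressed as a 2.4-fold higher number from compound 3 to compound 4 (0.38 log units; beyond the scatter). Compound 4 is thus estimated at 1.5 nM in this assay, with a range from 0.4 nM to 6 nM.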

Compound 4, half-maximal inhibitory concentration: 1.09 nM
The estimate for compound 4 lay 1.4-fold (0.14 log units) above the measured number; the measured number falls inside the stated range.
By their numbers in this assay, from the lowest: compounds 3 and 4 (each within the scatter of the next); then compound 1; then compound 2.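

In this assay, putting phenyl in place of methyl on a saturated chain carbon bound to an amine nitrogen in a ring, which can also be read as ethyl becoming benzyl, gives a 1.7-fold higher number from compound 3 to compound 4 (0.24 log units; within the scatter) and so leaves the two compounds indistinguishable. Going by these compounds alone, this is the first direct look at this outer position, and it shows that, for this pair, a group with a whole aromatic ring can take the place of a single methyl without a change that stands out from the ordinary variation between repeated measurements. Nothing available explains why the read-out holds steady across this change.

The compounds shown span only methyl and phenyl at this place, so it remains open whether the same tolerance extends to a carboxylic acid, a primary amine or a longer chain such as phenylethyl. From the compounds shown here alone, it is equally open whether a phenyl ring carrying a fluorine or a methoxy group, or a pyridine ring in its place, would keep the number this low.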